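Aryl-for-cyclohexyl swap on a β-lactam nitrogen: will saturation hold?

The source may report more compounds than this note shows. Statements on the series, on what has been measured and on what is new or still open speak of the compounds shown alone.

Measured so far:
compound 1 `COC(=O)c1nnn([C@@H]2C(=O)N(C3CCCCC3)[C@@H]2/C=C/c2ccccc2)c1C(=O)OC` gives 8.07%
compound 2 `O=C1[C@@H](n2cc(-c3ccccc3)nn2)[C@@H](/C=C/c2ccccc2)N1C1CCCCC1` gives 99.7%
compound 3 `COC(=O)c1nnn([C@@H]2C(=O)N(c3ccc(Cl)cc3)[C@@H]2/C=C/c2ccccc2)c1C(=O)OC` gives 56.5%

In a functional assay on KB cells (Homo sapiens) for inhibition, tested at 100 uM (on this read-out higher numbers stand for more inhibition of growth at the one concentration tested and lower numbers for less inhibition of growth), compound 2 stands highest of the three, with compound 3 nearest and compound 1 furthest. Compound 1 and compound 3 share a core, and the change between them is 4-chlorophenyl in place of cyclohexyl on an amide-type nitrogen in a ring; it made a step of a number 48.4 percentage points higher from compound 1 to compound 3 (beyond the scatter). Compound 2 has a different core; the difference between the two cores is not broken down here.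

Compound 4 `O=C1[C@@H](n2cc(-c3ccccc3)nn2)[C@@H](/C=C/c2ccccc2)N1c1ccc(Cl)cc1` has not yet been tested in this assay. It differs from compound 2 by 4-chlorophenyl in place of cyclohexyl on an amide-type nitrogen in a ring, the same change that carried compound 1 to compound 3. Within the data shown here, because compound 2 already gives 99.7%, close to full inhibition at the single concentration, there is little room for a further rise, so a much smaller step than the one from compound 1 to compound 3 is expected here. The expected step is about a number 1.7 percentage points lower from compound 2 to compound 4 (within the scatter). Compound 4 is accordingly estimated at 98%, with a plausible range from 88% to 100%.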

Compound 4, percent growth inhibition at one concentration: 79.3%
Estimate against measurement, compound 4: 18.7 percentage points above, and the stated range ends above it.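

In this assay, putting 4-chlorophenyl in place of cyclohexyl on the amide-type nitrogen did not act alike on the two cores: on the core of compound 2 it gave a number 20.4 percentage points lower from compound 2 to compound 4 (beyond the scatter), opposite in direction to the rise seen on the core of compound 1. Among these compounds, the comparison of the two steps shows that, in this series, neither the size nor the direction of the change can be carried from one core to the other: the same change on two cores in this assay, a number 48.4 percentage points higher (beyond the scatter) from compound 1 to compound 3 and a number 20.4 percentage points lower (beyond the scatter) from compound 2 to compound 4, 68.8 percentage points apart, beyond the scatter of two such steps It does not show which feature of the two cores separates the outcomes, nor how the change would act on any further core, as it rests on only two pairs of compounds read at a single concentration.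

On these data alone, it remains open whether a plain phenyl, or an aryl ring bearing an amine, on the amide-type nitrogen would follow compound 3 or compound 4. A third core, for example one carrying a carboxylic acid, would be needed to tell whether either step is typical of the series.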